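The source may report more compounds than this note shows. Statements on the series, on what has been measured and on what is new or still open speak of the compounds shown alone.

Measured so far in an ADME assay (liver) for pharmacokinetics, with Liver microsome (Homo sapiens) as the target, using microsomes; on this read-out higher numbers stand for a longer-lived compound and lower numbers for a shorter-lived compound:
- compound 1 `CCOc1cc(NC(=O)C2(NC(=O)c3ccc4c(C5CCCC5)c(-c5ncc(Cl)cn5)n(C)c4c3)CCC2)ccc1/C=C/C(=O)OCOP(=O)(O)O`: 0.167 h
- compound 2 `CCCOC(=O)/C=C/c1ccc(NC(=O)C2(NC(=O)c3ccc4c(C5CCCC5)c(-c5ncc(Cl)cn5)n(C)c4c3)CCC2)cc1OCC`: > 5 h (a limit of the assay)
- compound 3 `CCCCCCOC(=O)/C=C/c1ccc(NC(=O)C2(NC(=O)c3ccc4c(C5CCCC5)c(-c5ncc(Cl)cn5)n(C)c4c3)CCC2)cc1OCC`: 17.9 h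

Of the two true numbers in this assay, the higher belongs to compound 3 at 17.9 h. Going by the values given here, the only other number is that of compound 1, and the gap is a 110-fold higher number from compound 1 to compound 3 (2.03 log units; beyond the scatter).

Compound 4 `CCOc1cc(NC(=O)C2(NC(=O)c3ccc4c(C5CCCC5)c(-c5ncc(Cl)cn5)n(C)c4c3)CCC2)ccc1/C=C/C(=O)OCCOCCOC` changes the end of the ester chain of compound 3: 2-methoxyethoxy in place of butyl on a saturated chain carbon, two bonds along the chain from an oxygen next to a carbonyl group. In words, this is 2-methoxyethoxy in place of butyl.

Among the compounds with values here, no measured step makes this exact change. The nearest are a 110-fold higher number from compound 1 to compound 3 (2.03 log units; beyond the scatter) and an at least 29-fold higher number from compound 1 to compound 2 (1.47 log units; beyond the scatter), both large and both at the same end of the chain. The step that the limit leaves unreadable from compound 2 to compound 3 cannot be read. The entering group has no phosphorus, so a fall on the scale of a 110-fold higher number from compound 1 to compound 3 (2.03 log units; beyond the scatter) is not expected, but it does carry oxygen, unlike the leaving butyl. A moderate downward move is therefore expected.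

The expected step is a 3.0-fold lower number from compound 3 to compound 4 (0.47 log units; beyond the scatter).

For compound 4 the estimate is 6 h, with an expected range of 2 h to 18 h.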

Compound 4, half-life: 0.85 h
Compound 4: middle estimate off by 7.1-fold (0.85 log units), on the high side; the whole stated range lies above it.
By their numbers in this assay, from the lowest: compound 1; then compound 4; then compound 3.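

In this assay, a large fall at this end of the ester chain does not need phosphorus: 2-methoxyethoxy in place of butyl gives a 21-fold lower number from compound 3 to compound 4 (1.32 log units; beyond the scatter), and compound 2 also stands clear of compound 4, with an at least 5.8-fold lower number from compound 2 to compound 4 (0.76 log units; beyond the scatter). The 2-methoxyethoxy end still stays ahead of the phosphorus-bearing end, with a 5.1-fold higher number from compound 1 to compound 4 (0.71 log units; beyond the scatter), so the two oxygen-rich chain ends are not interchangeable here. Compound 2 is given as a limit, not a number, and its step to compound 3 cannot be read: the limit of > 5 h in this assay, at which 1 of the 4 values shown sits.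

As far as these compounds go, whether an ester chain ending in an amine or a carboxylic acid, or one holding a single ether oxygen, would sit nearer compound 3 or compound 4 stays open. The compounds shown also do not separate the effect of the oxygens in 2-methoxyethoxy from that of its chain length.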